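Carbamoylmethyl at the chain carbon of compound 2

This account rests on a few compounds, and the source may have more. Where it says the series, first, only, none or still open, it means among the compounds named here.

Compound 2 `C[C@H](NC(=O)CN(c1nc(Cl)nc2[nH]cnc12)C1CC1)C(=O)O` gives 44.6% in a functional assay on the whole organism (Tail, strain ICR) with Mus musculus as the target, in the tail flick test, with a stated time of 60 min, at a dose of 25 umol/kg by the oral route (on this read-out lower numbers stand for a weaker effect and higher numbers for a stronger effect at the one dose given), the highest of the three numbers seen. Compound 1 `O=C(O)[C@@H]1CCCN1C(=O)CN(c1nc(Cl)nc2[nH]cnc12)C1CC1` gives 34.9%, and the step of a number 9.7 percentage points higher from compound 1 to compound 2 (within the scatter) stays within the scatter. Going by the values given here, compound 3 `CC(C)C[C@H](NC(=O)CN(c1nc(Cl)nc2[nH]cnc12)C1CC1)C(=O)OCc1ccccc1` gives 27.3%, a gap to compound 2 beyond the scatter, though no single-place step joins these two. Compound 4 `NC(=O)CC[C@H](NC(=O)CN(c1nc(Cl)nc2[nH]cnc12)C1CC1)C(=O)O` differs from compound 2 by carbamoylmethyl in place of hydrogen on a saturated chain carbon, two bonds along the chain from an amide-type nitrogen and a carbonyl carbon. Among the compounds with values here, the only measured single-place step, a number 9.7 percentage points higher from compound 1 to compound 2 (within the scatter), exchanged one carboxy-bearing group for another without moving the number beyond the scatter; no measured pair adds a group of this kind to the chain. The expected step of a number 4.6 percentage points lower from compound 2 to compound 4 (within the scatter) is therefore none beyond the scatter, in either direction. Compound 4 is estimated at 40%, with a range of 25% to 55%.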

Compound 4, a percentage reported as activity, at one dose (the size of the read-out at that dose, not a potency): 38.4%
For compound 4 the middle estimate is 1.6 percentage points above the measured one; measured number inside the range.
By their numbers in this assay, from the lowest: compounds 3, 1, 4 and 2 (each within the scatter of the next, the first and the last beyond it).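

Carbamoylmethyl in place of hydrogen on this saturated chain carbon gives a number 6.2 percentage points lower from compound 2 to compound 4 (within the scatter) in this assay and is the first measured addition at this position. Read one bond further out, the change from methyl to 2-carbamoylethyl leaves the number within the scatter at the one dose given, so this position accepts the longer chain without a step beyond the scatter. No measured evidence bears on why the number holds at this position.

Still open, on these data alone, is whether an amine or a carboxylic acid in place of the terminal carbamoyl would move the number beyond the scatter. As far as these compounds go, a longer chain carrying the same carbamoyl also remains open.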